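Removing the Nitro Group from Compound 3

The source may report more compounds than this note shows. Statements on the series, on what has been measured and on what is new or still open speak of the compounds shown alone.

Compound 1 `Cn1c(=O)c(S(=O)(=O)c2ccc(Cl)cc2Cl)cc2cnc(Nc3ccc4[nH]ccc4c3)nc21` gives 1000 nM
Compound 2 `Cn1c(=O)c(S(=O)(=O)c2ccc(F)cc2)cc2cnc(Nc3ccc4[nH]ccc4c3)nc21` gives 300 nM
Compound 3 `Cn1c(=O)c(S(=O)(=O)c2ccc(F)cc2[N+](=O)[O-])cc2cnc(Nc3ccc4[nH]ccc4c3)nc21` gives 1500 nM

These values come from a functional assay on DU-145 cells (Homo sapiens) for inhibition, read by trypan blue exclusion, with a stated time of 72 h (on this read-out lower numbers stand for stronger inhibition and higher numbers for weaker inhibition), and so does every step below. Compound 3 has one close neighbour, shown by a 1.5-fold higher number from compound 1 to compound 3 (0.18 log units; within the scatter) and one clear gap, shown by a 5.0-fold higher number from compound 2 to compound 3 (0.70 log units; beyond the scatter) where nitro takes the place of hydrogen on an aromatic carbon.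

Compound 4 `Cn1c(=O)c(S(=O)(=O)c2ccc(N)cc2F)cc2cnc(Nc3ccc4[nH]ccc4c3)nc21` has 4-amino-2-fluorophenyl in place of 4-fluoro-2-nitrophenyl on a sulfonyl sulfur so the nitro group leaves. Changing the group on the sulfonyl sulfur also moved the number in a 3.3-fold lower number from compound 1 to compound 2 (0.52 log units; beyond the scatter) when 4-fluorophenyl replaced 2,4-dichlorophenyl. Among the measured compounds shown here, no measured compound carries an amino group, so the nitro step is only a rough guide. A lower number is therefore expected in this assay with an estimated 3.8-fold lower number from compound 3 to compound 4 (0.57 log units; beyond the scatter) as the likely size of the move. The estimate for compound 4 is 400 nM within an expected range of 100 nM to 1500 nM for a single measurement.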

Compound 4, half-maximal inhibitory concentration: 8000 nM
Compound 4: middle estimate off by 20-fold (1.30 log units), on the low side, and the stated range ends below it.
By their numbers in this assay, from the lowest: compound 2; then compounds 1 and 3 (each within the scatter of the next); then compound 4.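

Removing the nitro group from the aryl group on the sulfonyl sulfur did not restore activity in this assay: the number rose further when 4-amino-2-fluorophenyl replaced 4-fluoro-2-nitrophenyl (a 5.3-fold higher number from compound 3 to compound 4 (0.73 log units; beyond the scatter)). Compound 4 also trails the other two aryl groups (a 27-fold higher number from compound 2 to compound 4 (1.43 log units; beyond the scatter); an 8.0-fold higher number from compound 1 to compound 4 (0.90 log units; beyond the scatter)), which places it at the weak end of the four compounds shown. The earlier compounds shown here showed that adding a nitro group could raise the number, whereas this result shows that a ring without nitro can still give the highest number, so the absence of nitro alone does not secure activity.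

Nothing available here explains the rise. Going by these compounds, whether the amino group itself carries this cost remains open, and a hydroxyl or methoxy group on the same ring would help to test it.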